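Swapping the hydroxyethoxy pyridine for a hydroxypropyl pyrazole

A few compounds are considered here, and "the series" means these few. Any claim that something is new, unique, unknown or untested is made for them only; others in the source may bear on it.

In a functional assay on A549 cells (Homo sapiens) for antiproliferative activity, read by sulforhodamine B assay, with a stated time of 72 h (on this read-out lower numbers stand for stronger inhibition and higher numbers for weaker inhibition), compound 3 `COc1ncc(-c2ccc3ncnc(Nc4ccc(OCCO)nc4)c3c2)cc1NS(=O)(=O)c1ccc(F)cc1F` gives 4120 nM, the second highest of the three numbers measured, though every gap is within the scatter. Compound 2 `COC(=O)Cn1cc(Nc2ncnc3ccc(-c4cnc(OC)c(NS(=O)(=O)c5ccc(F)cc5F)c4)cc23)cn1` gives 4280 nM in this assay, and the step of a 1.0-fold lower number from compound 2 to compound 3 (0.02 log units; within the scatter) is within the scatter; compound 1 `COc1ncc(-c2ccc3ncnc(Nc4ccc(OCCO)cc4)c3c2)cc1NS(=O)(=O)c1ccc(F)cc1F` gives 2690 nM, and a 1.5-fold higher number from compound 1 to compound 3 (0.19 log units; within the scatter) is likewise within the scatter. Compound 4 `COc1ncc(-c2ccc3ncnc(Nc4cnn(CCCO)c4)c3c2)cc1NS(=O)(=O)c1ccc(F)cc1F` differs from compound 3 by 1-(3-hydroxypropyl)-1H-pyrazol-4-yl in place of 6-(2-hydroxyethoxy)pyridin-3-yl on a nitrogen on an aromatic ring. All three measured steps vary the same group on that nitrogen, and none, including a 1.6-fold higher number from compound 1 to compound 2 (0.20 log units; within the scatter), moved beyond the scatter; compound 2 already carries a pyrazol-4-yl there. Compound 4 is therefore expected to show no step beyond the scatter, a 1.0-fold lower number from compound 3 to compound 4 (0.01 log units; within the scatter), in this assay. Compound 4 is estimated at 4000 nM, with a range from 1800 nM to 9000 nM.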

Compound 4, half-maximal inhibitory concentration: 4830 nM
The estimate for compound 4 lay 1.2-fold (0.08 log units) below the measured number, and the stated range covers the measured number.
By their numbers in this assay, from the lowest: compounds 1, 3, 2 and 4 (each within the scatter of the next).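

In this assay, the 1-(3-hydroxypropyl)-1H-pyrazol-4-yl group on this nitrogen shows a 1.2-fold higher number from compound 3 to compound 4 (0.07 log units; within the scatter) and a 1.8-fold higher number from compound 1 to compound 4 (0.25 log units; within the scatter), so it stays within the scatter of both the pyridine and the phenyl groups. The change on the pyrazole itself, 2-hydroxyethyl in place of methoxycarbonyl on the saturated chain carbon, gives a 1.1-fold higher number from compound 2 to compound 4 (0.05 log units; within the scatter) and also stays within the scatter, so the ester and the alcohol are not told apart here. No available evidence bears on this result.

As far as these compounds go, whether a primary amine or a carboxylic acid at the end of that chain would move the number beyond the scatter remains open. The same holds for a longer chain.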